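The compounds below may be only part of what the source reports. "The series", "measured", "known", "first", "only" and "open" are said of these compounds alone.

Compound 1 `O=C(c1ccccc1)c1ccn(-c2ccc3c(c2)B(O)OC3)c1` in an ADME assay on L929 cells (Mus musculus) for cytotoxicity, read by resazurin assay, with a stated time of 72 h (on this read-out higher numbers stand for weaker inhibition and lower numbers for stronger inhibition), gives > 10 ug/mL, which is a limit of the assay and not a number. Compound 2 `Nc1ccc(C(=O)c2ccn(-c3ccc4c(c3)B(O)OC4)c2)cc1` in this assay gives 3.9 ug/mL.

Compound 2 therefore holds the only number shown in this assay; the one further value is a limit. Compound 3 `O=C(CCc1ccccc1)c1ccn(-c2ccc3c(c2)B(O)OC3)c1` has not yet been measured. It differs from compound 2 by phenethyl in place of 4-aminophenyl on a carbonyl carbon. Within the data shown here, the only measured step that bears on this change is an at least 2.5-fold lower number from compound 1 to compound 2 (0.40 log units; beyond the scatter), in which an amino group entered; compound 3 removes that amino group again and carries phenethyl in place of the 4-aminophenyl. A step of comparable size in the opposite direction is therefore expected, that is a higher number, quite possibly reaching (the limit of > 10 ug/mL in this assay, at which 1 of the 2 values shown sits). For compound 3 the estimate in this assay is 10 ug/mL, between 4 ug/mL and 25 ug/mL, meaning an expected step of a 2.6-fold higher number from compound 2 to compound 3 (0.41 log units; beyond the scatter).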

Compound 3, half-maximal inhibitory concentration: > 10 ug/mL
Compound 3 ended at the assay's limit; the forecaster's own chance of this, stated with the estimate: 50%; the middle value sits exactly at the limit.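

In this assay, the change on the carbonyl carbon from 4-aminophenyl to phenethyl gives an at least 2.5-fold higher number from compound 2 to compound 3 (0.40 log units; beyond the scatter). The value of compound 3 is a limit of the assay and not a number, and the step between compound 1 and compound 3, phenethyl in place of phenyl, cannot be read. Among the compounds shown, only compound 2 carries an amino group and only compound 2 gives a number, while compound 1 and compound 3 both end at the limit: the limit of > 10 ug/mL in this assay, at which 2 of the 3 values shown sit.

As far as these compounds go, how far compound 1 and compound 3 lie past the limit stays unknown, so phenyl and phenethyl cannot be ranked against each other. From the compounds shown here alone, whether the lower number depends on the amino group specifically also stays open, and 4-hydroxyphenyl, 4-(dimethylamino)phenyl or a phenethyl chain carrying an amine on the carbonyl carbon would bear on that.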